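This account rests on a few compounds, and the source may have more. Where it says the series, first, only, none or still open, it means among the compounds named here.

Series notes. Compound 1 `CCc1oc2c(C)c(OCc3ccccc3)ccc2c(=O)c1Br` is measured in a functional assay on KBVIN cells (Homo sapiens) for antiproliferative activity, read by sulforhodamine B assay, with a stated time of 72 h; on this read-out higher numbers stand for weaker inhibition of growth and lower numbers for stronger inhibition of growth. In this assay compound 1 reaches only a limit, > 26700 nM. Compound 2 `CCc1cc(=O)c2ccc(OC)c(CBr)c2o1` likewise reaches only a limit in this assay, > 33600 nM. Going by the values given here, compound 3 `COc1ccc2c(=O)cc(C(C)Br)oc2c1CBr` gives 17000 nM in this assay, the only number among the three values shown. The other two values sit at limits, the limit of > 26700 nM in this assay, at which 1 of the 3 values shown sits, and (the limit of > 33600 nM in this assay, at which 1 of the 3 values shown sits). Among the compounds with values here, the single measured step, an at least 1.9-fold lower number from compound 2 to compound 3 (0.29 log units; that floor lies within the scatter), concerns a different change and does not touch the alkoxy group. Compound 4 `CC(C)Oc1ccc2c(=O)cc(C(C)Br)oc2c1CBr` differs from compound 3 by isopropyl in place of methyl on an oxygen on an aromatic ring. Within the data shown here, no measured step bears on this change, so no direction can be drawn from the three compounds. For compound 4 in this assay a value of 17000 nM is expected, with a range from 6000 nM to 50000 nM, which means an expected step of no change at the digits printed from compound 3 to compound 4 (within the scatter).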

Compound 4, concentration for 50% growth inhibition: 11400 nM
Estimate against measurement, compound 4: 1.5-fold (0.17 log units) above, within the range that was stated.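

In this assay, going by these compounds alone, the change from methoxy to isopropoxy gives a 1.5-fold lower number from compound 3 to compound 4 (0.17 log units; within the scatter), the first reading of any change on this oxygen on an aromatic ring. Compound 3 and compound 4 therefore stand level, and isopropyl takes the place of methyl with no shift that can be read beyond the scatter. Nothing shown gives a cause for this step.

Going by these compounds, whether a longer chain or an amine on this oxygen would move the number beyond the scatter stays open. Within the data shown here, also open is whether the same change reads alike on another core, since only this one pair bears on it.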